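A Second Hydroxy Group: What the Step May Bring

The source may report more compounds than this note shows. Statements on the series, on what has been measured and on what is new or still open speak of the compounds shown alone.

Of the compounds shown here, two have been measured. Compound 1 `N#Cc1c(Nc2ccc(O)cc2)nc(SCC(=O)Nn2c(COc3ccc(Cl)cc3Cl)nc3ccccc3c2=O)nc1-c1ccc(Cl)cc1` and compound 2 `N#Cc1c(Nc2ccccc2)nc(SCC(=O)Nn2c(COc3ccc(Cl)cc3Cl)nc3ccccc3c2=O)nc1-c1ccc(O)cc1` share one core and differ only in where a single hydroxy group sits. In a functional assay on the whole organism (strain albino) for inhibition, with Rattus norvegicus as the target, read by paw edema, with stated times of 1 h and 2 h, at a dose of 100 mg/kg by the oral route (a higher number here means more inhibition at the dose given (going by the name of the read-out), a lower number less inhibition), compound 1 gives 91.2%, and compound 2 gives 91.2%. Compound 2 thus stands level with compound 1, with no change at the digits shown. Compound 3 `N#Cc1c(Nc2ccc(O)cc2)nc(SCC(=O)Nn2c(COc3ccc(Cl)cc3Cl)nc3ccccc3c2=O)nc1-c1ccc(O)cc1` carries both hydroxy groups at once; from compound 2 the change is hydroxy in place of hydrogen on an aromatic carbon. The step of a number 1.2 percentage points lower from compound 2 to compound 3 (within the scatter) is expected to stay within the scatter, in no clear direction. Compound 3 is estimated at 90%, within a range from 78% to 97%.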

Compound 3, a percentage reported as inhibition, in the whole organism at one dose (the size of the read-out at that dose, not a potency): 86.8%
Compound 3: middle estimate off by 3.2 percentage points, on the high side, within the range that was stated.
By their numbers in this assay, from the lowest: compounds 3, 1 and 2 (each within the scatter of the next).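

In this assay, hydroxy in place of hydrogen, turning anilino into (4-hydroxyphenyl)amino, gives a number 4.4 percentage points lower from compound 2 to compound 3 (within the scatter), so a second hydroxy group brings no clear shift in the read-out. Hydroxy in place of chloro on an aromatic carbon gives a number 4.4 percentage points lower from compound 1 to compound 3 (within the scatter), so these two groups cannot be told apart here either. Nothing available explains these results.

On these data alone, whether an amine or a carboxylic acid at these positions would separate the compounds stays open. A single oral dose also leaves any difference in potency unknown.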